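Phenyl to 4-methoxypyrimidin-5-yl: an open stability question

The source may hold more compounds than are shown below. What is called first, only, known or untested is meant among the compounds shown, and "the series" means these compounds.

Of the compounds shown here, two with a shared core have so far been measured in an ADME assay on S9 fraction from liver (Rattus norvegicus) for metabolic stability, with a stated time of 1 h; on this read-out lower numbers stand for a less stable compound and higher numbers for a more stable compound. Compound 1 (`N#Cc1cnc(NCc2ccccc2C(F)(F)F)cc1N[C@H]1CC[C@@H](O)CC1`) gives 31%, and compound 2 (`N#Cc1cnc(NCc2ccccc2)cc1N[C@H]1CC[C@@H](O)CC1`) gives 64%, the higher of the two numbers. For the measured compounds named here, the single measured step, a number 33 percentage points higher from compound 1 to compound 2 (beyond the scatter), comes with hydrogen in place of trifluoromethyl on an aromatic carbon, and it is large.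

Compound 3 (`COc1ncncc1CNc1cc(N[C@H]2CC[C@@H](O)CC2)c(C#N)cn1`) has not yet been measured. It differs from compound 2 at one place: 4-methoxypyrimidin-5-yl in place of phenyl on a saturated chain carbon bound to a nitrogen on an aromatic ring. This is 4-methoxypyrimidin-5-yl in place of phenyl on a saturated chain carbon bound to a nitrogen on an aromatic ring.

The measured step bears on this only indirectly. Going by the values given here, it concerns the aromatic ring that now leaves, yet it involves no exchange of that ring, and no measured compound carries a ring with hetero atoms. The size of a number 33 percentage points higher from compound 1 to compound 2 (beyond the scatter) nevertheless argues for a wide range, while the direction remains weakly supported. The expected change is a number 4 percentage points higher from compound 2 to compound 3 (within the scatter), a small rise at most. Compound 3 is estimated at 68%, with an expected range from 45% to 88%.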

Compound 3, percent of the compound remaining: 89%
The estimate for compound 3 lay 21 percentage points below the measured number; measured number outside the range, above it.
By their numbers in this assay, from the lowest: compound 1; then compound 2; then compound 3.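

In this assay, the change from phenyl to 4-methoxypyrimidin-5-yl gives a number 25 percentage points higher from compound 2 to compound 3 (beyond the scatter), which shows that at this place on a saturated chain carbon bound to a nitrogen on an aromatic ring, the number responds to the identity of the ring itself. For the compounds shown here, until now the only measured change here was the removal of trifluoromethyl from a ring that stayed all carbon, whereas this step brings in a ring with 2 hetero atoms and a group with 3 hydrogen-bond acceptors, and the number again moves upward beyond the scatter. No measurement at hand accounts for this rise, so the reason for it stays unexplained.

The step brings in the ring nitrogens and the methoxy group together, so the compounds shown cannot assign the rise to either one, and a plain pyrimidin-5-yl or a phenyl carrying methoxy would be needed to separate them. As far as these compounds go, it also remains open whether trifluoromethyl on the new ring would lower the number as it does on phenyl, and whether a different ring, such as a pyridine, would behave like 4-methoxypyrimidin-5-yl.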